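Swapping a halogen on the aryl ring of compound 2

The source may report more compounds than this note shows. Statements on the series, on what has been measured and on what is new or still open speak of the compounds shown alone.

Of the compounds shown here, three have been tested in a functional assay on U-251 cells (Homo sapiens) for antiproliferative activity; a lower number here means a stronger inhibitor of growth, a higher number a weaker inhibitor of growth. Compound 2, with the structure `Cc1cnc2[nH]c(-c3cccc(F)c3)cc(=O)c2c1`, gives the lowest number of the three, 40.7 nM. Compound 1, whose structure is `Cc1cccc(-c2cc(O)c3cc(C)cnc3n2)c1`, is its nearest neighbour, and in this assay compound 1 gives 170 nM, a gap that goes beyond the usual scatter. Compound 3, with the structure `Cc1cc(C)c2c(O)cc(-c3ccc4ccccc4c3)nc2n1`, stands furthest away, since in this assay compound 3 gives 15800 nM. Compound 2 therefore stands as the strongest growth inhibitor among the three, with every gap to the others beyond the scatter.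

Compound 4, whose structure is `Cc1cnc2[nH]c(-c3cccc(Cl)c3)cc(=O)c2c1`, has not yet been measured. It differs from compound 2 in one place only: chloro in place of fluoro on an aromatic carbon. The change is a single heavy atom exchanged for another of the same kind, on an aromatic carbon of a six-membered aromatic ring of carbon only. For the measured compounds named here, no measured pair here shows what such a swap does, so the expected step in this assay from compound 2 to compound 4 is small, possibly none beyond the scatter, and its direction is uncertain. On that basis compound 4 is estimated at 35 nM, within a range of 12 nM to 120 nM, which means an expected step of a 1.2-fold lower number from compound 2 to compound 4 (0.07 log units; within the scatter).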

Compound 4, concentration for 50% growth inhibition: 69.2 nM
Estimate against measurement, compound 4: 2.0-fold (0.30 log units) below, and the stated range covers the measured number.
By their numbers in this assay, from the lowest: compounds 2 and 4 (each within the scatter of the next); then compound 1; then compound 3.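

In this assay, for the compounds shown here, this is the first pair of compounds that differ at a single place, the carbon of the aromatic ring that sits meta to a large group, and chloro in place of fluoro there gives a 1.7-fold higher number from compound 2 to compound 4 (0.23 log units; within the scatter), a step within the scatter. The two halogens therefore cannot be told apart at this position in this read-out, so the strong growth inhibition seen for compound 2 does not depend on fluoro alone and is kept with chloro in compound 4. No measurement of any property of these two groups accompanies this result, so what lies behind it cannot be said.

What the compounds shown leave open is whether this position accepts only a halogen, since a single swap between two halogens says nothing about how a methoxy group, an amine or a carboxylic acid would behave at the same carbon. From the compounds shown here alone, it also remains open whether chloro and fluoro would read alike at other places on the ring, or with a bromo group or plain hydrogen at this one.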